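The source may hold more compounds than are shown below. What is called first, only, known or untested is meant among the compounds shown, and "the series" means these compounds.

Compound 1 `CC(C)CCn1nc(C(=O)N[C@H]2COc3ccccc3N(C)C2=S)nc1Cc1ccccc1` gives 3640 nM in a functional assay on HT-29 cells (Homo sapiens) for inhibition, read by luminescence and CellTiter-Glo, with a stated time of 24 h; a higher number here means that more compound is needed for the effect, a lower number that less compound is needed. Compound 2 `CN1C(=S)[C@@H](NC(=O)c2nc(Cc3ccccc3)n(CCCF)n2)COc2ccccc21` gives 4760 nM in this assay, with a 1.3-fold higher number from compound 1 to compound 2 (0.12 log units; within the scatter). For the measured compounds named here, compound 2 thus sits together with compound 1, the only other measured compound, inside the scatter. Compound 3 `CN1C(=S)[C@@H](NC(=O)c2nc(Cc3ccccc3)n(C3COC3)n2)COc2ccccc21` carries oxetan-3-yl in place of 3-fluoropropyl on an aromatic nitrogen. Going by the values given here, only the step from compound 1 to compound 2 concerns a group on the same aromatic nitrogen, and that step stayed within the scatter. The change is expected to leave the number roughly in place, a 1.1-fold lower number from compound 2 to compound 3 (0.02 log units; within the scatter). Compound 3 is therefore estimated at 4500 nM, within a range of 1500 nM to 13000 nM.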

Compound 3, half-maximal effective concentration: 916 nM
Estimate against measurement, compound 3: 4.9-fold (0.69 log units) above; the measured number lies below the stated range.
By their numbers in this assay, from the lowest: compound 3; then compounds 1 and 2 (each within the scatter of the next).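

In this assay the group on this aromatic nitrogen proves able to move the number beyond the scatter: oxetan-3-yl gives a lower number than either open chain (a 5.2-fold lower number from compound 2 to compound 3 (0.72 log units; beyond the scatter); a 4.0-fold lower number from compound 1 to compound 3 (0.60 log units; beyond the scatter)). The earlier step, between two open chains, had shown no such movement. Nothing measured here accounts for the drop. The compounds shown leave open whether the lower number goes with the four-membered ring or with its oxygen. A cyclobutyl group, which keeps the ring without the oxygen, and a 2-methoxyethyl chain, which keeps an oxygen without the ring, would separate the two.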